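From Dimethylamino to (Piperidin-1-yl)carbonyl on the Shared Core

This account rests on a few compounds, and the source may have more. Where it says the series, first, only, none or still open, it means among the compounds named here.

In a toxicity assay on NIH3T3 cells (Mus musculus) for cytotoxicity, read by resazurin assay (a higher number here means that more compound is needed for the effect, a lower number that less compound is needed), compound 1 (`CN(C)c1ccc(NCc2cncn2Cc2ccc(-c3ccccc3)cc2)cc1-c1ccccc1`) gives > 1000 nM, which is a limit and not a number. Compound 2 (`COC(=O)c1ccc(NCc2cncn2Cc2cccc([N+](=O)[O-])c2)cc1-c1ccccc1`) gives > 10000 nM, also a limit. Compound 3 (`COC(=O)c1ccc(NCc2cncn2Cc2ccc(N)cc2)cc1-c1ccccc1`) gives > 10000 nM, again a limit. None of the three compounds therefore has a readable value, and compound 1 can be placed only by its limit.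

Compound 4 (`O=C(c1ccc(NCc2cncn2Cc2ccc(-c3ccccc3)cc2)cc1-c1ccccc1)N1CCCCC1`) has (piperidin-1-yl)carbonyl in place of dimethylamino on an aromatic carbon. Going by the values given here, the only measured step is a step that the two limits leave unreadable from compound 2 to compound 3. It concerns a different group from the one changed here and has no readable size, so it gives no size to carry over to compound 4.

The expectation therefore rests on the limits alone. None of the three compounds reaches a measured effect in this assay, so compound 4 is expected to need a high concentration too, and a report of only a limit is likely. The expected change is a step that the limit leaves unreadable from compound 1 to compound 4, an estimate with a wide margin and a direction that is only tentative. For compound 4 the estimated value is 8000 nM, within an expected range from 2000 nM to 30000 nM.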

Compound 4, half-maximal effective concentration: > 1000 nM
Compound 4: only a limit was reported (the forecaster's own chance of this, stated with the estimate: 75%); the middle value lies beyond the limit too.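

In this assay compound 4 gives > 1000 nM, which is a limit and not a number. Compound 1 gives > 1000 nM, also a limit. Going by these compounds alone, no step from compound 1 to compound 4 can therefore be read. The compounds shown leave open what concentration of either compound produces the effect, and whether (piperidin-1-yl)carbonyl in place of dimethylamino alters it.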